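Closing the Acid Side Chain into a Three-Membered Ring

A few compounds are considered here, and "the series" means these few. Any claim that something is new, unique, unknown or untested is made for them only; others in the source may bear on it.

Of the compounds shown here, two have been measured so far. In a functional assay on CHO cells for antagonist activity at sphingosine 1-phosphate receptor 2 (Homo sapiens), read by calcium flux (on this read-out lower numbers stand for stronger inhibition and higher numbers for weaker inhibition), compound 1, `O=C(O)Cn1nc(Cc2nc3cc(Cl)c(OC(F)(F)F)cc3[nH]2)c2ccccc2c1=O`, gives 31 nM. In this assay compound 2, `C[C@@H](C(=O)O)c1nn(Cc2cn3cc(OCC4CC4)c(Cl)cc3n2)c2ccccc2c1=O`, gives 24 nM.

Compound 2 holds the lower of the two numbers, but compound 1 sits within the usual scatter of it, so the two cannot be told apart on these numbers alone.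

Compound 3, `O=C(O)C1(c2nn(Cc3cn4cc(OCC5CC5)c(Cl)cc4n3)c3ccccc3c2=O)CC1`, is the next to be measured. It differs from compound 2 in one place: 1-carboxycyclopropyl in place of 1-carboxyethyl on an aromatic carbon. The acid is kept; what changes is that the single methyl branch beside it is closed into a small ring, which also removes the defined stereocentre of compound 2.

Among the measured compounds shown here, no pair of measured compounds differs in this one place, so nothing measured here shows how such a change moves the number. With no such guide, the step expected from compound 2 to compound 3 is a 1.0-fold higher number from compound 2 to compound 3 (0.02 log units; within the scatter), none beyond the scatter. On that basis compound 3 is expected to give about 25 nM, with a range from 8 nM to 80 nM.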

Compound 3, half-maximal inhibitory concentration: 16 nM
Compound 3: middle estimate off by 1.6-fold (0.19 log units), on the high side; the measured number falls inside the stated range.
By their numbers in this assay, from the lowest: compounds 3, 2 and 1 (each within the scatter of the next).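

Among the compounds shown here, this is the first pair that differs only in this acid side chain. In this assay, the change gives a 1.5-fold lower number from compound 2 to compound 3 (0.18 log units; within the scatter), so compound 2 and compound 3 cannot be told apart, and this position accepts 1-carboxycyclopropyl as well as 1-carboxyethyl, even with one more heavy atom, a three-membered ring and no defined stereocentre. Nothing measured here offers an explanation for this result.

The step changes several things at once, so it cannot show whether the ring or the loss of the stereocentre matters more; a side chain with two methyl groups on the carbon bearing the acid, which has no ring and no stereocentre, would help to separate them. Still open, on these data alone, is how this position would respond to a larger ring, such as 1-carboxycyclobutyl, or to a primary amide or a tetrazole in place of the carboxylic acid.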